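The source may hold more compounds than are shown below. What is called first, only, known or untested is meant among the compounds shown, and "the series" means these compounds.

Measured compounds:
- Compound 1 `O=C(COc1ccc(C(=O)/C=C/c2cccc(Cl)c2)cc1)N[C@H]1CCOC1=O` — 20900 nM
- Compound 2 `CC(C)(C)c1ccc(/C=C/C(=O)c2ccc(OCC(=O)N[C@H]3CCOC3=O)cc2)cc1` — 16400 nM
- Compound 3 `CC(C)c1ccc(/C=C/C(=O)c2ccc(OCC(=O)N[C@H]3CCOC3=O)cc2)cc1` — 23400 nM

These values come from a functional assay on MCF7 cells (Homo sapiens) for antiproliferative activity, read by MTT assay, with a stated time of 72 h; a lower number here means a stronger inhibitor, a higher number a weaker inhibitor. Compound 3 holds the highest of the three numbers, but the step of a 1.1-fold higher number from compound 1 to compound 3 (0.05 log units; within the scatter) and the step of a 1.4-fold higher number from compound 2 to compound 3 (0.15 log units; within the scatter) both stay within the scatter, so no ordering among the three is secure. Compound 4 `O=C(COc1ccc(C(=O)/C=C/c2cccc(Br)c2)cc1)N[C@H]1CCOC1=O` is not yet measured; it differs from compound 3 by 3-bromophenyl in place of 4-isopropylphenyl on a double-bonded chain carbon bound to a double-bonded chain carbon. The step that bears most on this change is a 1.1-fold higher number from compound 1 to compound 3 (0.05 log units; within the scatter), where a 3-chlorophenyl gave way to the 4-isopropylphenyl with no shift beyond the scatter; compound 4 returns to a similar 3-substituted phenyl. The expected step is therefore a 1.2-fold lower number from compound 3 to compound 4 (0.07 log units; within the scatter), nothing beyond the scatter. Compound 4 is estimated at 20000 nM, within a range from 9000 nM to 45000 nM.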

Compound 4, half-maximal inhibitory concentration: 28300 nM
Compound 4: the middle estimate sits 1.4-fold (0.15 log units) below what was measured; measured number inside the range.
By their numbers in this assay, from the lowest: compounds 2, 1, 3 and 4 (each within the scatter of the next).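

In this assay, 3-bromophenyl on a double-bonded chain carbon bound to a double-bonded chain carbon cannot be told apart from 4-isopropylphenyl (a 1.2-fold higher number from compound 3 to compound 4 (0.08 log units; within the scatter)) or from 4-(tert-butyl)phenyl (a 1.7-fold higher number from compound 2 to compound 4 (0.24 log units; within the scatter)). The identity of the halogen on the aromatic carbon also shows no readable effect, with bromo in place of chloro (a 1.4-fold higher number from compound 1 to compound 4 (0.13 log units; within the scatter)). No supporting data explain this flat picture.

Going by these compounds, whether a phenyl ring carrying an amine or a carboxylic acid would give a number beyond the scatter stays open.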